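From Methyl to Phenyl on the Five-Membered Ring

The compounds below may be only part of what the source reports. "The series", "measured", "known", "first", "only" and "open" are said of these compounds alone.

Of the compounds shown here, three of one shared core have been measured in an assay on membranes from heart (Cavia porcellus) for binding affinity to Voltage-dependent L-type calcium channel subunit alpha-1C (Homo sapiens); on this read-out higher numbers stand for weaker inhibition and lower numbers for stronger inhibition. Compound 1 `COC(=O)C1=C(C)N=C(C)/C(=C(/O)OC)C1c1c(C)noc1C` gives 122 nM. Compound 2 `CCOC(=O)C1=C(C)N=C(C)/C(=C(/O)OCC)C1c1c(C)noc1CC` gives 52 nM. Compound 3 `CCOC(=O)C1=C(C)N=C(C)/C(=C(/O)OCC)C1c1c(C)noc1C` gives 27.1 nM, the lowest of the three numbers; its nearest neighbour is compound 2, whose number lies within the scatter of it, while compound 1 lies beyond the scatter above it. Among the compounds with values here, the only step between measured compounds that differ in one place is a 1.9-fold lower number from compound 2 to compound 3 (0.28 log units; within the scatter), which swaps hydrogen for methyl on a saturated chain carbon bound to an aromatic carbon, and it stays within the scatter.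

Compound 4 `CCOC(=O)C1=C(C)N=C(C)/C(=C(/O)OCC)C1c1c(-c2ccccc2)noc1C` departs from compound 3 by phenyl in place of methyl on an aromatic carbon. Within the data shown here, no measured step touches that aromatic carbon, so the step from compound 2 to compound 3 offers only an indirect hint: a change on the same ring has not moved the number beyond the scatter. The account therefore expects a step of a 1.7-fold higher number from compound 3 to compound 4 (0.22 log units; within the scatter) in this assay, modest in size and uncertain in direction. Compound 4 is estimated at 45 nM, with an expected range from 10 nM to 200 nM.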

Compound 4, inhibition constant: 13.9 nM
Compound 4: the middle estimate sits 3.2-fold (0.51 log units) above what was measured; measured number inside the range.
By their numbers in this assay, from the lowest: compounds 4, 3 and 2 (each within the scatter of the next, the first and the last beyond it); then compound 1.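

Within the data shown here, this is the first reading on the aromatic carbon next to the ring nitrogen itself: in this assay, phenyl in place of methyl gives a 1.9-fold lower number from compound 3 to compound 4 (0.29 log units; within the scatter) and so stays within the scatter. The place therefore accepts a group of 6 heavy atoms, including a six-membered aromatic ring of carbon only, where there was 1 heavy atom, without a change that can be told from repeated measurement, and this holds for the pair compound 3 and compound 4 alone. Nothing at hand bears on why the number holds through this exchange.

With only methyl and phenyl seen at this aromatic carbon, the compounds shown leave open whether an amine, a carboxylic acid or a longer chain such as butyl would also stay within the scatter of compound 3. They also leave open whether a phenyl carrying a chlorine or a methoxy group, or a pyridine ring in its place, would move the number beyond the scatter in either direction.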